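The source may hold more compounds than are shown below. What is called first, only, known or untested is meant among the compounds shown, and "the series" means these compounds.

Compound 1 `NS(=O)(=O)OC[C@H]1O[C@@H](n2ccc(=O)[nH]c2=O)C[C@@H]1O` and compound 2 `NS(=O)(=O)NC(=O)OC[C@H]1O[C@@H](n2ccc(=O)[nH]c2=O)C[C@@H]1O` share a core. In an in vitro assay on BL21-DE3 cells for inhibition of Deoxyuridine 5'-triphosphate nucleotidohydrolase, mitochondrial (Homo sapiens) (on this read-out higher numbers stand for weaker inhibition and lower numbers for stronger inhibition), compound 1 reaches only the limit > 1000000 nM. In this assay compound 2 likewise reaches only the limit > 1000000 nM. The step that the two limits leave unreadable from compound 1 to compound 2 is therefore unreadable, both values sitting at the limit of > 1000000 nM in this assay, at which 2 of the 2 values shown sit. Compound 3 `CC(C)(C)[Si](C)(C)O[C@H]1C[C@H](n2ccc(=O)[nH]c2=O)O[C@@H]1COC(=O)NS(N)(=O)=O` differs from compound 2 by a group of 7 heavy atoms (6 carbon, 1 silicon; no ring) in place of a hydrogen atom, on an oxygen on a saturated carbon. Going by the values given here, no measured step bears on this change, and compound 2 offers only a limit, so no shift beyond the scatter can be foreseen in this assay. Compound 3 is expected to give 1000000 nM, most probably again as a limit. The step this estimate means is a number no higher from compound 2 to compound 3 (the limit leaves the size open).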

Compound 3, inhibition constant: > 1000000 nM
Compound 3: only a limit was reported; the forecaster's own chance of this, stated with the estimate: 85%; the middle value sits exactly at the limit.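

Compound 3 gives only the limit > 1000000 nM in this assay, so no new step can be read from compound 2 to compound 3: the limit of > 1000000 nM in this assay, at which 3 of the 3 values shown sit. The compounds shown leave open how strongly any of them inhibits the enzyme, and whether the group of 7 heavy atoms changes that inhibition at all.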